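The compounds below may be only part of what the source reports. "The series", "measured", "known", "first", "only" and "open" are said of these compounds alone.

The measured compounds are: compound 1 `CS(=O)(=O)Nc1ccc([N+](=O)[O-])cc1OCc1ccc(F)cc1` with 580 nM in an assay on SK-BR-3 cells for inhibition of Aromatase (Homo sapiens); a lower number here means a stronger inhibitor, a higher number a weaker inhibitor; compound 2 `CS(=O)(=O)Nc1ccc([N+](=O)[O-])cc1OCc1ccc(Cl)cc1` with 290 nM; and compound 3 `CS(=O)(=O)Nc1ccc([N+](=O)[O-])cc1OCc1ccc(Br)cc1` with 5850 nM.

Compound 3 stands highest of the three, the weakest inhibitor in this assay, with compound 1 nearest a 10-fold higher number from compound 1 to compound 3 (1.00 log units; beyond the scatter) and compound 2 furthest a 20-fold higher number from compound 2 to compound 3 (1.30 log units; beyond the scatter). The unmeasured compound 4 `Cc1ccc(C)c(COc2cc([N+](=O)[O-])ccc2NS(C)(=O)=O)c1` differs from compound 3 by 2,5-dimethylphenyl in place of 4-bromophenyl on a saturated chain carbon bound to an oxygen on an aromatic ring. Among the compounds with values here, no measured step introduces a dimethyl pattern, so none bears directly on it; the halogen steps only show that a change at this phenyl can move the number a great deal in either direction, as a 2.0-fold lower number from compound 1 to compound 2 (0.30 log units; within the scatter) and a 20-fold higher number from compound 2 to compound 3 (1.30 log units; beyond the scatter) together illustrate. With wide uncertainty, compound 4 is therefore expected to move back toward the range of the other two, with an estimated step of a 3.9-fold lower number from compound 3 to compound 4 (0.59 log units; beyond the scatter). Compound 4 is estimated at 1500 nM, between 300 nM and 8000 nM.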

Compound 4, half-maximal inhibitory concentration: 370 nM
For compound 4 the middle estimate is 4.1-fold (0.61 log units) above the measured one, within the range that was stated.
By their numbers in this assay, from the lowest: compounds 2, 4 and 1 (each within the scatter of the next); then compound 3.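

The 2,5-dimethylphenyl group, with a 16-fold lower number from compound 3 to compound 4 (1.20 log units; beyond the scatter), shows that this position can carry a phenyl ring without halogen and with two methyl groups, and still leave the number well clear of that of compound 3. Compound 4 also sits level with the two lighter halogen compounds, with a 1.3-fold higher number from compound 2 to compound 4 (0.11 log units; within the scatter) and a 1.6-fold lower number from compound 1 to compound 4 (0.20 log units; within the scatter), so among these four the high number belongs to the 4-bromophenyl group alone. No evidence here explains this difference.

Open, as far as these compounds go, is whether a 4-iodophenyl group would share the high number of compound 3. Also open, from the compounds shown here alone, is how a single methyl group, a methoxy group or an amine on this ring would compare.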